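A few compounds are considered here, and "the series" means these few. Any claim that something is new, unique, unknown or untested is made for them only; others in the source may bear on it.

Compound 1 `COc1ccc(CS(=O)(=O)/C=C/c2c(OC)cccc2OC)cc1` is the best point of reference here. In a functional assay on DU-145 cells (Homo sapiens) for antiproliferative activity, read by trypan blue exclusion (a higher number here means a weaker inhibitor, a lower number a stronger inhibitor), compound 1 gives 250 nM. Compound 3 `COc1ccc(CS(=O)(=O)/C=C/c2c(OC)cc(O)cc2OC)cc1` carries one more group, (hydroxy in place of hydrogen on an aromatic carbon). In this assay compound 3 reaches only a limit, > 20000 nM. That single change gave an at least 80-fold higher number from compound 1 to compound 3 (1.90 log units; beyond the scatter). Compound 2 `COc1ccc(CS(=O)(=O)/C=C/c2cc(OC)c(OC)c(OC)c2)cc1` has a different core; how the two cores differ is not broken down here. In this assay compound 2 also reaches only a limit, > 20000 nM. Compound 4 `COc1ccc(CS(=O)(=O)/C=C/c2cc(OC)c(OC)c(OC)c2)cc1O` has not yet been measured; it differs from compound 2 by hydroxy in place of hydrogen on an aromatic carbon. This is the same kind of change as from compound 1 to compound 3, though the place differs: there the hydroxy sat meta to two methoxy groups and para to a large group, here it sits ortho to a methoxy group and meta to a large group. Compound 2 already sits at the limit, and the step of an at least 80-fold higher number from compound 1 to compound 3 (1.90 log units; beyond the scatter) gives no hint that a hydroxy helps, so for compound 4 the expectation is a step that the limit leaves unreadable from compound 2 to compound 4. The estimate for compound 4 in this assay is 40000 nM, expected between 15000 nM and 150000 nM.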

Compound 4, half-maximal inhibitory concentration: 5000 nM
Estimate against measurement, compound 4: 8.0-fold (0.90 log units) above, outside the stated range (below it).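

In this assay, the same change ran the opposite way on the two cores, so it did not carry over from one to the other: the same change on two cores in this assay, an at least 80-fold higher number (1.90 log units; beyond the scatter) from compound 1 to compound 3 and an at least 4.0-fold lower number (0.60 log units; beyond the scatter) from compound 2 to compound 4, at least 320-fold (2.50 log units) apart, beyond the scatter of two such steps. The new step is an at least 4.0-fold lower number from compound 2 to compound 4 (0.60 log units; beyond the scatter), but compound 2 and compound 3 each stand at a limit of the assay and not at a number, so neither step has an exact size: the limit of > 20000 nM in this assay, at which 2 of the 4 values shown sit. The hydroxy also sits in a different place in compound 3 and compound 4, so these compounds cannot tell whether the core or the place decides the outcome.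

The compounds shown leave open whether a 3-hydroxy-4-methoxyphenyl group would behave the same way on the core of compound 1. They also leave open whether an amine or a fluorine atom in place of the hydroxy of compound 4 would give a similar step.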